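Isopropyl for dimethoxy across two related cores

The source may report more compounds than this note shows. Statements on the series, on what has been measured and on what is new or still open speak of the compounds shown alone.

Compound 1 `COc1ccc(-c2cc(-c3ccc4c(c3)CCCC4)nc3[nH]nc(N)c23)cc1OC` and compound 2 `CC(C)c1ccc(-c2cc(-c3ccc4c(c3)CCCC4)nc3[nH]nc(N)c23)cc1` share one core; compound 3 `COc1ccc(-c2cc(-c3ccc4c(c3)CCCC4)nc(NCc3ccccc3)c2C#N)cc1OC` and compound 4 `CC(C)c1ccc(-c2cc(-c3ccc4c(c3)CCCC4)nc(NCc3ccccc3)c2C#N)cc1` share another, and the difference between the two cores is not broken down here. In an ADME assay on RAW264.7 cells (Mus musculus) for cytotoxicity, with a stated time of 24 h (on this read-out lower numbers stand for stronger inhibition and higher numbers for weaker inhibition), compound 1 gives only a limit, > 50000 nM. In this assay compound 2 likewise gives only a limit, > 50000 nM. The change 4-isopropylphenyl in place of 3,4-dimethoxyphenyl on an aromatic carbon therefore leaves a step that the two limits leave unreadable from compound 1 to compound 2, owing to the limit of > 50000 nM in this assay, at which 2 of the 3 values shown sit. In this assay, among the compounds with values here, compound 3 gives 4900 nM, the only number in the set. The change to compound 4, (4-isopropylphenyl in place of 3,4-dimethoxyphenyl on an aromatic carbon), is the same kind of change, but its place differs: ortho to a cyano group and meta to a benzylamino group, rather than part of a fused or bridged system of two rings, ortho to a fused ring and meta to a fused ring. With the earlier step unreadable, the step of a 1.2-fold higher number from compound 3 to compound 4 (0.09 log units; within the scatter) is expected to stay small, resting on compound 3 at 4900 nM alone. Compound 4 is estimated at 6000 nM, between 2000 nM and 20000 nM.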

Compound 4, half-maximal inhibitory concentration: > 50000 nM
Compound 4 ended at the assay's limit; the forecaster's own chance of this, stated with the estimate: 25%; at least 8.3-fold (0.92 log units) between middle value and limit.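

On the core carrying the benzylamino group, 4-isopropylphenyl in place of 3,4-dimethoxyphenyl gives an at least 10-fold higher number from compound 3 to compound 4 (1.00 log units; beyond the scatter) in this assay. Going by these compounds, compound 4 gives only a limit, > 50000 nM, not a number, so the full size of this step stays unknown. The same change on the core of compound 1 cannot be read, so the notes show a clear step on one core only and do not show that it carries over to the other: the limit of > 50000 nM in this assay, at which 3 of the 4 values shown sit.

Still open, on these data alone, is how a carboxylic acid or an amine on that phenyl ring would read in this assay on either core. Also open, as far as these compounds go, is whether any group on the core of compound 1 would give a number rather than a limit.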